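Pyridinyl Replacement of the Benzoyl Arm in the Chromene Series

The compounds below may be only part of what the source reports. "The series", "measured", "known", "first", "only" and "open" are said of these compounds alone.

Measured so far:
Compound 1, `CC1(C)C=C(n2ccccc2=O)c2cc(C(=O)c3ccccc3)ccc2O1`: 6.61
Compound 2, `CC1(C)C=C(n2ccccc2=O)c2cc(C(=O)c3ccccc3F)ccc2O1`: 7.08
Compound 3, `Cc1ccccc1C(=O)c1ccc2c(c1)C(n1ccccc1=O)=CC(C)(C)O2`: 6.83

All three values come from a functional assay (aorta) with Rattus norvegicus as the target; on this read-out higher numbers stand for higher potency (the scale is a negative logarithm) and lower numbers for lower potency. Compound 3 stands second highest of the three numbers: its nearest neighbour is compound 1, a number 0.22 log units higher from compound 1 to compound 3 (within the scatter), and its furthest is compound 2, a number 0.25 log units lower from compound 2 to compound 3 (within the scatter), both within the scatter. For the measured compounds named here, the only step beyond the scatter is a number 0.47 log units higher from compound 1 to compound 2 (beyond the scatter).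

Compound 4, `CC1(C)C=C(n2ccccc2=O)c2cc(-c3ccncc3)ccc2O1`, is not yet measured. Its change from compound 3 is pyridin-4-yl in place of (2-methylphenyl)carbonyl on an aromatic carbon. None of the three measured steps is of this kind: each of them only alters a hydrogen, fluoro or methyl on the aromatic ring of the leaving group, whereas here the whole (2-methylphenyl)carbonyl leaves and pyridin-4-yl enters at the same place. Going by the values given here, the measured steps therefore give little direct guidance; they show only that small changes at this arm move this assay by at most a modest amount, as in the step from compound 1 to compound 2.

Among the compounds with values here, with no comparable precedent, the expectation for compound 4 is set near the middle of the measured range, with a wide band. For compound 4 the expected value in this assay is 6.6, estimated to lie between 5.7 and 7.4. The estimated step this implies is a number 0.23 log units lower from compound 3 to compound 4 (within the scatter), expected to fall within the scatter in either direction.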

Compound 4, logarithm of the reciprocal of the active concentration, log(1/C): 6.68
The estimate for compound 4 lay 0.08 log units below the measured number; low and high end bracket the measured number.
By their numbers in this assay, from the lowest: compounds 1, 4, 3 and 2 (each within the scatter of the next, the first and the last beyond it).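

In this assay, the whole (2-methylphenyl)carbonyl arm gives way to pyridin-4-yl with a number 0.15 log units lower from compound 3 to compound 4 (within the scatter), and the exchange for benzoyl reads a number 0.07 log units higher from compound 1 to compound 4 (within the scatter). For the compounds shown here, the carbonyl and the larger arm are therefore not needed at this aromatic carbon to stay at the level of these two compounds, a point the earlier steps could not address because each of them kept the carbonyl in place. Only the fluorinated arm stands apart, with a number 0.40 log units lower from compound 2 to compound 4 (beyond the scatter), so pyridin-4-yl does not match the number held by (2-fluorophenyl)carbonyl. No measurement in hand bears on why the numbers fall this way.

The compounds shown do not separate the role of the ring nitrogen from the loss of the carbonyl: a plain phenyl and a pyridin-3-yl on the same aromatic carbon would address that directly. Also open, going by these compounds, are whether a fluoro on the pyridin-4-yl ring reaches the level of compound 2 at 7.08, and how groups of another kind, such as a carboxylic acid or an amine, read at this place.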